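This account rests on a few compounds, and the source may have more. Where it says the series, first, only, none or still open, it means among the compounds named here.

Measured in a functional assay on a cell-free system (plasma, Oryctolagus cuniculus) for inhibition, with stated times of 5 min, 1 min and 6 min; a lower number here means a stronger inhibitor, a higher number a weaker inhibitor:

- Compound 1 `CCOC(=O)c1c(C)nc(-c2cccc(C#N)c2)n1C`: 22100 nM
- Compound 2 `CCOC(=O)c1c(C)nc(-c2cccc(C#N)c2)n1OCCC(=O)O`: > 30000 nM, a limit of the assay and not a number
- Compound 3 `CCOC(=O)c1c(C)nc(-c2cccc(C#N)c2)n1OCc1ccncc1`: 6200 nM

Of the two true numbers in this assay, compound 3 holds the lower. The step to it is a 3.6-fold lower number from compound 1 to compound 3 (0.55 log units; beyond the scatter). Compound 2 offers only a limit, so its step to compound 3 is a bound, given as an at least 4.8-fold lower number from compound 2 to compound 3 (0.68 log units; beyond the scatter).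

Compound 4 `CCOC(=O)c1c(C)nc(-c2cccc(C#N)c2)n1OCc1ccc(Cl)cc1` has not yet been measured. It carries 4-chlorophenyl in place of pyridin-4-yl on a saturated chain carbon bound to an oxygen on an aromatic ring.

Only the second of those steps changes the same place, and it swaps carboxymethyl rather than one aromatic ring for another. The step of a 3.6-fold lower number from compound 1 to compound 3 (0.55 log units; beyond the scatter) replaces the whole group on the aromatic nitrogen. Neither step measures the present exchange directly, and both compounds keep a six-membered aromatic ring there. No step beyond the scatter is therefore expected in this assay, though a slight drift to a lower number is allowed for. The estimate corresponds to an expected 1.2-fold lower number from compound 3 to compound 4 (0.09 log units; within the scatter). For compound 4 the estimated value is 5000 nM, with an expected range from 1500 nM to 17000 nM.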

Compound 4, half-maximal inhibitory concentration: 6830 nM
Estimate against measurement, compound 4: 1.4-fold (0.14 log units) below; the measured number falls inside the stated range.
By their numbers in this assay, from the lowest: compounds 3 and 4 (each within the scatter of the next); then compound 1. At a limit, above all of these: compound 2.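

In this assay, the exchange on a saturated chain carbon bound to an oxygen on an aromatic ring gives the first direct comparison of one six-membered aromatic ring with another, and it yields a 1.1-fold higher number from compound 3 to compound 4 (0.04 log units; within the scatter), so the ring nitrogen of pyridin-4-yl is not required at this place among the compounds shown. The 4-chlorobenzyl ether also keeps the difference from the methyl compound, with a 3.2-fold lower number from compound 1 to compound 4 (0.51 log units; beyond the scatter), which means that both compounds with an aromatic ring at this place, compound 3 and compound 4, have lower numbers than compound 1. Compound 2 sits at a limit of the assay and not at a number, so an at least 4.3-fold lower number from compound 2 to compound 4 (0.64 log units; beyond the scatter) is only a bound, and how far the carboxylic acid chain really lies from either aromatic group stays unknown: the limit of > 30000 nM in this assay, at which 1 of the 4 values shown sits.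

The compounds shown leave open what the chlorine itself contributes, since a plain benzyl group, a 4-fluorobenzyl or a 4-methoxybenzyl group does not appear among them. They also leave open whether a longer chain carrying the same ring, or an amine on that chain, would behave like compound 3 and compound 4.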